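The compounds below may be only part of what the source reports. "The series", "measured", "known", "first", "only" and "open" are said of these compounds alone.

Working notes on the series. Compound 1 `COc1cc(CNCc2ccncc2)ccc1OCc1ccc(C)cc1` is the reference point; in a functional assay on HeLa cells (Homo sapiens) for inhibition, with a stated time of 72 h (a lower number here means that less compound is needed, a higher number that more compound is needed for the effect), compound 1 gives 5000 nM, the lowest of the two numbers available. Compound 3 `COc1cc(CNCCSc2nnnn2C)ccc1OCc1ccc(Cl)nc1` gives 86000 nM in this assay, a number well beyond the scatter above that of compound 1. Compound 2 `COc1cc(CNCc2ccc(C(=O)O)cc2)ccc1OCc1ccc(Cl)nc1` has no number in this assay; the entry reads "nd(insoluble)" (no result reported), so it contributes nothing to the comparison.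

Compound 4 `COc1cc(CNCc2ccncc2)ccc1OCc1ccc([N+](=O)[O-])cc1` is the next candidate. It keeps the core of compound 1 and differs at one place: nitro in place of methyl on an aromatic carbon. Cut one bond further out, the change reads 4-methylphenyl to 4-nitrophenyl, the group sitting para to a large group. Going by the values given here, no measured pair shows this exchange, so there is no step to lean on; the only anchor is the value of compound 1.

The change is expected to move the number little, with no clear direction, so the step from compound 1 to compound 4 is estimated as a 1.2-fold higher number from compound 1 to compound 4 (0.08 log units; within the scatter). For compound 4 in this assay the estimate is 6000 nM, with a range from 1500 nM to 25000 nM.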

Compound 4, half-maximal effective concentration: 440 nM
Beside the measured number, compound 4's estimate is 14-fold (1.13 log units) above it, and the stated range ends above it.
By their numbers in this assay, from the lowest: compound 4; then compound 1; then compound 3.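

Going by these compounds alone, the exchange of 4-methylphenyl for 4-nitrophenyl gives in this assay an 11-fold lower number from compound 1 to compound 4 (1.06 log units; beyond the scatter) and is the first step that can be read at a single place. The aromatic carbon para to a large group is therefore a place where one change alone, with the rest of compound 1 held fixed, moves the number well beyond the scatter. Nothing available on these compounds accounts for the size or direction of this step.

As far as these compounds go, one pair gives one exchange, so it stays open whether the step belongs to the nitro group in particular or would also appear with an amine or a nitrile on the same carbon. Within the data shown here, also open is whether the same exchange gives a step of this size with a side chain other than the one in compound 1.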